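A few compounds are considered here, and "the series" means these few. Any claim that something is new, unique, unknown or untested is made for them only; others in the source may bear on it.

Working notes on the series in an ADME assay on BJ cells (Homo sapiens) for antiproliferative activity, with a stated time of 72 h; on this read-out higher numbers stand for an effect only at larger amounts of compound and lower numbers for an effect already at smaller amounts.

Compound 1 `COc1ccc(-c2c(Cl)c(=O)c3c(OC)cc(OC)cc3n2S(=O)(=O)c2ccc(OC)cc2)cc1` gives 90000 nM in this assay. Compound 2 `COC(=O)c1cc(=O)c2c(OC)cc(OC)cc2[nH]1` returns only a limit of the assay, > 34400 nM, and not a number. Compound 3 `COc1ccc(-c2cc(=O)c3c(OC)cc(OC)cc3n2S(=O)(=O)c2ccc(C=O)cc2)cc1` likewise returns only a limit of the assay, > 34400 nM. That is where compound 3 stands on the numbers shown: of the three values, two sit at the limit of > 34400 nM in this assay, at which 2 of the 3 values shown sit, and the single numerical value belongs to compound 1. Going by the values given here, no pair of the measured compounds differs in a single place, so no measured step is at hand to calibrate the change below.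

Compound 4 `COc1ccc(-c2cc(=O)c3c(OC)cc(OC)cc3n2S(=O)(=O)c2ccc(Cl)cc2)cc1` has not yet been measured in this assay. It differs from compound 3 by chloro in place of formyl on an aromatic carbon of a six-membered aromatic ring of carbon only, para to a large group. Since compound 3 sits at a limit, there is no fixed starting number. The expected step is a step that the limit leaves unreadable from compound 3 to compound 4, which is taken as lying within the scatter, with no shift beyond it in either direction. Compound 4 is therefore expected to give about 50000 nM in this assay, within 20000 nM to 150000 nM. A further limit rather than a number is considered a fair possibility for compound 4.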

Compound 4, half-maximal effective concentration: > 34400 nM
Compound 4: only a limit was reported; the forecaster's own chance of this, stated with the estimate: 60%; the middle value does not contradict the limit.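

Like compound 3, compound 4 returns only a limit of the assay, > 34400 nM, in this assay. No step can therefore be read between the two compounds, and the limit is shared with most of the series: the limit of > 34400 nM in this assay, at which 3 of the 4 values shown sit.

The compounds shown leave open whether chloro in place of formyl changes the read-out in either direction.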